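Chlorobenzyl series: moving the chlorine round the ring

This account rests on a few compounds, and the source may have more. Where it says the series, first, only, none or still open, it means among the compounds named here.

Compound 1 `COc1ccc(C2N=C(SCc3ccccc3Cl)NC(C)=C2C(=O)Nc2ccc(F)cc2)cc1OC` gives 30.3% in a functional assay on the whole organism (artery, strain albino) with Rattus norvegicus as the target, with a stated time of 240 min, at a dose of 10 mg/kg by the oral route; on this read-out higher numbers stand for more inhibition at the one dose given (going by the name of the read-out) and lower numbers for less inhibition. Compound 2 `COc1ccc(C2N=C(SCc3cccc(Cl)c3)NC(C)=C2C(=O)Nc2ccc(F)cc2)cc1OC` gives 14.9% and stands lowest of the two numbers. Among the measured compounds shown here, the only measured change at this position is a number 15.4 percentage points lower from compound 1 to compound 2 (beyond the scatter). Compound 3 `COc1ccc(C2N=C(SCc3ccc(Cl)cc3)NC(C)=C2C(=O)Nc2ccc(F)cc2)cc1OC` differs from compound 2 by 4-chlorophenyl in place of 3-chlorophenyl on a saturated chain carbon bound to a sulfur. For the measured compounds named here, no measured step covers the move to 4-chlorophenyl; the single earlier step shows that shifting the chlorine can move the read-out beyond the scatter, but gives no direction for this case. Compound 3 is expected near 18%, between 4% and 34%, an estimated step of a number 3.1 percentage points higher from compound 2 to compound 3 (within the scatter) that is expected to stay within the scatter.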

Compound 3, a percentage reported as inhibition, in the whole organism at one dose (the size of the read-out at that dose, not a potency): 24.1%
Compound 3: middle estimate off by 6.1 percentage points, on the low side, within the range that was stated.
By their numbers in this assay, from the lowest: compounds 2, 3 and 1 (each within the scatter of the next, the first and the last beyond it).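

In this assay the steps of a number 9.2 percentage points higher from compound 2 to compound 3 (within the scatter) and a number 6.2 percentage points lower from compound 1 to compound 3 (within the scatter) place 4-chlorophenyl within the scatter of both other chlorophenyl groups. Only 2-chlorophenyl and 3-chlorophenyl remain apart, so the three compounds give no graded order with the place of the chlorine. Nothing available explains these numbers. Still open, as far as these compounds go, is whether a methoxy group or a nitrile on this ring, or a longer chain in place of the benzyl carbon, would hold or change the read-out.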